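Predicting clearance of a chlorophenyl analogue in liver microsomes

The source may hold more compounds than are shown below. What is called first, only, known or untested is meant among the compounds shown, and "the series" means these compounds.

Compound 1 `O=S(=O)(c1ccc(F)c(F)c1)c1cnc2c(F)cccc2c1-c1ccc(Cl)cc1`: 0.28 mL/min
Compound 2 `COc1ccc(S(=O)(=O)c2cnc3c(F)cccc3c2-c2ccc(Cl)cc2)cc1`: 1.05 mL/min
Compound 3 `N#Cc1cccc(S(=O)(=O)c2cnc3c(F)cccc3c2-c2cccc(F)c2)c1`: 0.34 mL/min

In an ADME assay on microsomes from liver (Homo sapiens) for metabolic stability, tested at 2.5 uM (on this read-out higher numbers stand for fast clearance and lower numbers for slow clearance), compound 3 gives 0.34 mL/min, a number close to that of compound 1, while compound 2 gives 1.05 mL/min, a larger number. For the measured compounds named here, the one measured step, a 3.8-fold higher number from compound 1 to compound 2 (0.57 log units; beyond the scatter), concerns the group on the sulfonyl sulfur and does not touch the position changed here. Compound 4 `N#Cc1cccc(S(=O)(=O)c2cnc3c(F)cccc3c2-c2ccc(Cl)cc2)c1` differs from compound 3 by 4-chlorophenyl in place of 3-fluorophenyl on an aromatic carbon. Going by the values given here, no measured pair informs this change, so no step beyond the scatter is expected in this assay. The value of compound 4 is therefore estimated at 0.34 mL/min, with a range from 0.17 mL/min to 0.7 mL/min, which means an expected step of no change at the digits printed from compound 3 to compound 4 (within the scatter).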

Compound 4, intrinsic clearance in a liver preparation (reported as CLH), per the amount of preparation that the assay uses: 0.08 mL/min
For compound 4 the middle estimate is 4.3-fold (0.63 log units) above the measured one; measured number outside the range, below it.
By their numbers in this assay, from the lowest: compound 4; then compounds 1 and 3 (each within the scatter of the next); then compound 2.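

In this assay the group on the aromatic carbon opposite the ring nitrogen proves to matter, with 4-chlorophenyl in place of 3-fluorophenyl giving a 4.3-fold lower number from compound 3 to compound 4 (0.63 log units; beyond the scatter). With 4-chlorophenyl held there, 3-cyanophenyl on the sulfonyl sulfur gives a 13-fold lower number from compound 2 to compound 4 (1.12 log units; beyond the scatter) and a 3.5-fold lower number from compound 1 to compound 4 (0.54 log units; beyond the scatter). Nothing available explains either change. As far as these compounds go, it remains open whether the step seen with 4-chlorophenyl would hold with the other groups on the sulfonyl sulfur. Also open, from the compounds shown here alone, is how an amine or a carboxylic acid on that phenyl ring would read.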